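Notes on a caspase-8 series: aldehyde warhead variant

The source may hold more compounds than are shown below. What is called first, only, known or untested is meant among the compounds shown, and "the series" means these compounds.

Measured compounds:
compound 1, `CCC(C(=O)N[C@@H](CC(=O)O)C(=O)CSCc1ccccc1)n1ccnc(NCC2COc3ccccc3O2)c1=O`: 8220 nM
compound 2, `CCC(C(=O)N[C@@H](CC(=O)O)C(=O)CSCc1ccccc1)n1ccnc(NCc2cc(C)no2)c1=O`: 3300 nM
compound 3, `CCC(C(=O)N[C@@H](CC(=O)O)C(=O)CNCN1CCCC1)n1ccnc(NCc2nonc2C)c1=O`: 6220 nM

In an assay for inhibition of Caspase-8 (Homo sapiens) (a higher number here means a weaker inhibitor, a lower number a stronger inhibitor), compound 3 stands second highest of the three numbers; its gap to compound 1 and to compound 2 is within the scatter in each case. Within the data shown here, the only measured step, a 2.5-fold lower number from compound 1 to compound 2 (0.40 log units; beyond the scatter), concerns the substituent on the saturated chain carbon bound to the ring nitrogen, not the carbonyl end, so nothing measured bears directly on the change to compound 4, `CCC(C(=O)N[C@H](C=O)CC(=O)O)n1ccnc(NCc2nonc2C)c1=O`. That change is hydrogen in place of (((pyrrolidin-1-yl)methyl)amino)methyl on a carbonyl carbon. Among the measured compounds shown here, with no step at this position to go on, the size and direction of a 2.5-fold lower number from compound 3 to compound 4 (0.40 log units; beyond the scatter) is an expectation only, and a wide one. Compound 4 is estimated at 2500 nM in this assay, between 600 nM and 10000 nM.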

Compound 4, half-maximal inhibitory concentration: 990 nM
The estimate for compound 4 lay 2.5-fold (0.40 log units) above the measured number; measured number inside the range.
By their numbers in this assay, from the lowest: compound 4; then compounds 2, 3 and 1 (each within the scatter of the next, the first and the last beyond it).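

In this assay, among these compounds, hydrogen in place of (((pyrrolidin-1-yl)methyl)amino)methyl on a carbonyl carbon gives a 6.3-fold lower number from compound 3 to compound 4 (0.80 log units; beyond the scatter), the first measured step at this position. The number therefore responds to the carbonyl end, and losing all 8 heavy atoms of that group does not weaken inhibition. Nothing available accounts for this step.

Still open, on these data alone, is whether the lower number belongs to the formyl group alone. A methyl or a plain aminomethyl on the same carbonyl carbon would show how much of the group can return.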